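The compounds below may be only part of what the source reports. "The series", "measured", "known", "first", "only" and "open" are said of these compounds alone.

The series shares one core: compound 1 is `CCC(C)n1ncn(-c2ccc(N3CCN(c4ccc(OC[C@@H]5CO[C@@](Cn6cnc(C)n6)(c6ccc(Cl)cc6Cl)O5)cc4)CC3)cc2)c1=O`, compound 2 is `CCC(C)n1ncn(-c2ccc(N3CCN(c4ccc(OC[C@@H]5CO[C@@](Cn6ccnc6C(C)C)(c6ccc(Cl)cc6Cl)O5)cc4)CC3)cc2)c1=O`, compound 3 is `CCC(C)n1ncn(-c2ccc(N3CCN(c4ccc(OC[C@@H]5CO[C@@](Cn6cc(C)nc6C)(c6ccc(Cl)cc6Cl)O5)cc4)CC3)cc2)c1=O` and compound 4, not yet measured, is `CCC(C)n1ncn(-c2ccc(N3CCN(c4ccc(OC[C@@H]5CO[C@@](Cn6nnnc6-c6ccccc6)(c6ccc(Cl)cc6Cl)O5)cc4)CC3)cc2)c1=O`. Among the compounds with values here, in a functional assay on HUVEC cells (Homo sapiens), read by scintillation counting and thymidine incorporation, with a stated time of 24 h (on this read-out lower numbers stand for stronger inhibition and higher numbers for weaker inhibition), compound 1 gives 272 nM, the second highest of the three numbers known; compound 2 gives 84 nM and compound 3 gives 492 nM. The step to compound 4 is 5-phenyl-1H-tetrazol-1-yl in place of 3-methyl-1H-1,2,4-triazol-1-yl on a saturated chain carbon bound to a saturated ring carbon. Two measured steps alter the same group: a 3.2-fold lower number from compound 1 to compound 2 (0.51 log units; beyond the scatter), while a 1.8-fold higher number from compound 1 to compound 3 (0.26 log units; within the scatter). Neither brings in a tetrazole or a phenyl, so the direction for compound 4 is uncertain; the 2-isopropyl-1H-imidazol-1-yl of compound 2 gave the lower number, the 2,4-dimethyl-1H-imidazol-1-yl of compound 3 nothing beyond the scatter. A modest move downward or none is expected, a 1.4-fold lower number from compound 1 to compound 4 (0.16 log units; within the scatter). Compound 4 is estimated at 190 nM, between 60 nM and 600 nM.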

Compound 4, half-maximal inhibitory concentration: 119 nM
Beside the measured number, compound 4's estimate is 1.6-fold (0.20 log units) above it; low and high end bracket the measured number.
By their numbers in this assay, from the lowest: compounds 2 and 4 (each within the scatter of the next); then compounds 1 and 3 (each within the scatter of the next).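

In this assay, the position on a saturated chain carbon bound to a saturated ring carbon accepts 5-phenyl-1H-tetrazol-1-yl, a larger group with a second aromatic ring, with a 2.3-fold lower number from compound 1 to compound 4 (0.36 log units; beyond the scatter) and a 4.1-fold lower number from compound 3 to compound 4 (0.62 log units; beyond the scatter). Against 2-isopropyl-1H-imidazol-1-yl there is a 1.4-fold higher number from compound 2 to compound 4 (0.15 log units; within the scatter), so these two different groups read alike here. No data at hand explain these differences.

As far as these compounds go, whether the phenyl or the tetrazole carries the lower number stays open; an unsubstituted 1H-tetrazol-1-yl or 5-methyl-1H-tetrazol-1-yl would separate them. Also open, from the compounds shown here alone, is the effect of an amine or carboxylic acid on that phenyl.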